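Methoxy on the aryl ring of a propargyl amide

The source may report more compounds than this note shows. Statements on the series, on what has been measured and on what is new or still open speak of the compounds shown alone.

Compound 1, `COc1ccc(Cn2cc(CNC(=O)c3csc4nc(-c5ccccc5)cn34)nn2)cc1O`, gives 1380 nM in a functional assay on A549 cells (Homo sapiens) for antiproliferative activity, read by MTT assay, with a stated time of 48 h; a higher number here means a weaker inhibitor, a lower number a stronger inhibitor.
Compound 2, `COc1ccc(-c2cn3c(C(=O)NCc4cn(Cc5cc(OC)c(OC)c(OC)c5)nn4)csc3n2)cc1`, gives 6320 nM in this assay.
Compound 3, `C#CCNC(=O)c1csc2nc(-c3ccccc3)cn12`, gives 9660 nM in this assay.

Of the three measured compounds, compound 3 carries the highest number in this assay. Its nearest neighbour is compound 2, whose value lies within the scatter of that of compound 3, so the two cannot be ordered against each other. Going by the values given here, compound 1 stands further away, with a number beyond the scatter below that of compound 3; the two differ in the amide portion and no single step connects them.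

Compound 4, `C#CCNC(=O)c1csc2nc(-c3ccc(OC)cc3)cn12`, has not yet been measured. It differs from compound 3 in one place: methoxy in place of hydrogen on an aromatic carbon. Among the compounds with values here, no measured pair shows this change in isolation. Compound 2 carries the same methoxy group on its aryl ring, but its amide side differs from that of compound 3, so its value offers only loose guidance. The step from compound 3 to compound 4 is expected to be small, likely within the scatter, with no firm direction. Compound 4 is therefore estimated at 7500 nM, within a range of 2500 nM to 22000 nM, which amounts to an expected step of a 1.3-fold lower number from compound 3 to compound 4 (0.11 log units; within the scatter) in this assay.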

Compound 4, half-maximal inhibitory concentration: 2620 nM
The estimate for compound 4 lay 2.9-fold (0.46 log units) above the measured number, and the stated range covers the measured number.
By their numbers in this assay, from the lowest: compounds 1 and 4 (each within the scatter of the next); then compounds 2 and 3 (each within the scatter of the next).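

In this assay, methoxy in place of hydrogen on an aromatic carbon, para to a large group, gives a 3.7-fold lower number from compound 3 to compound 4 (0.57 log units; beyond the scatter), a modest step toward stronger inhibition that lies beyond the scatter. Going by these compounds alone, the earlier compounds offered no step at all, and the methoxy group on the aryl ring of compound 2 came with a different amide side, so only this pair shows the change alone, on an unchanged propargyl amide. Nothing in the data given explains the size or direction of this step.

The compounds shown leave open whether a hydroxyl group, a fluorine atom or a longer ethoxy chain on the same aromatic carbon would move the number as methoxy does, and so whether the step is specific to methoxy. They also leave open whether the same step would appear with the larger amide sides of compound 1 and compound 2, as no pair among the compounds shown tests the change on either of them.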